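Demethylation of the Benzylamine Aryl Ether in a Diphenylamine Series

The source may report more compounds than this note shows. Statements on the series, on what has been measured and on what is new or still open speak of the compounds shown alone.

Measured compounds:
compound 1, `COc1cc(Oc2cccc(Nc3ccccc3)c2)cc(OC)c1CNC1CC1`, > 20000 nM
compound 2, `COc1ccc(CNCc2c(OC)cc(Oc3cccc(Nc4ccccc4)c3)cc2OC)cc1`, 2620 nM
compound 3, `COc1ccc([C@@H](C)NCc2c(OC)cc(Oc3cccc(Nc4ccccc4)c3)c(OC)c2OC)cc1`, 2440 nM

In a functional assay on HCT-116 cells (Homo sapiens) for inhibition, read by MTT assay, with a stated time of 72 h (a higher number here means a weaker inhibitor, a lower number a stronger inhibitor), compound 1 reaches only the assay limit, (the limit of > 20000 nM in this assay, at which 1 of the 3 values shown sits), so its value is not a number. Compound 2 gives 2620 nM in this assay, the highest of the two numbers shown; compound 3, which gives 2440 nM, sits within the scatter of it, so no order between compound 2 and compound 3 can be read.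

Compound 4 is `COc1cc(Oc2cccc(Nc3ccccc3)c2)cc(OC)c1CNCc1ccc(O)cc1`. It differs from compound 2 as follows: hydrogen in place of methyl on an oxygen on an aromatic ring. Among the measured compounds shown here, the only measured step in this set is an at least 7.6-fold lower number from compound 1 to compound 2 (0.88 log units; beyond the scatter), which concerns the group on the amine nitrogen and not the oxygen on the aromatic ring, so no measured step bears directly on the change from 4-methoxybenzyl to 4-hydroxybenzyl. With nothing to point either way, the expected step is a 1.1-fold higher number from compound 2 to compound 4 (0.03 log units; within the scatter), no change beyond the scatter. Compound 4 is therefore estimated at 2800 nM, within 1000 nM to 8000 nM.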

Compound 4, half-maximal inhibitory concentration: 3360 nM
Compound 4: the middle estimate sits 1.2-fold (0.08 log units) below what was measured; the range from low to high includes it.
By their numbers in this assay, from the lowest: compounds 3, 2 and 4 (each within the scatter of the next). At a limit, above all of these: compound 1.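

In this assay, hydrogen in place of methyl on the oxygen on the aromatic ring, the change from 4-methoxybenzyl to 4-hydroxybenzyl, leaves the reading within the scatter: a 1.3-fold higher number from compound 2 to compound 4 (0.11 log units; within the scatter). With either group on the amine nitrogen, the reading stays clearly apart from that with cyclopropyl, since an at least 5.9-fold lower number from compound 1 to compound 4 (0.77 log units; beyond the scatter) lies beyond the scatter just as an at least 7.6-fold lower number from compound 1 to compound 2 (0.88 log units; beyond the scatter) does, so this separation does not depend on the methyl on that oxygen. Compound 1 gives no number for these comparisons, only a limit of the assay: the limit of > 20000 nM in this assay, at which 1 of the 4 values shown sits.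

The compounds shown leave open whether an amine or a carboxylic acid in place of the hydroxy would move the reading beyond the scatter. They also leave open whether the same exchange of methoxy for hydroxy gives a similar result on the core of compound 3.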